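Phenyl in Place of Chloro in a Sodium/Hydrogen Exchanger Series

This account rests on a few compounds, and the source may have more. Where it says the series, first, only, none or still open, it means among the compounds named here.

Measured compounds:
Compound 1 `Cc1cc(Cl)c(S(C)(=O)=O)cc1C(=O)N=C(N)N`: 25 nM
Compound 2 `Cc1c(C(=O)N=C(N)N)cc(S(C)(=O)=O)c(Cl)c1C`: 58 nM
Compound 3 `Cc1cc(-c2cc(C(F)(F)F)cc(C(F)(F)F)c2)c(S(C)(=O)=O)cc1C(=O)N=C(N)N`: 2800 nM

In a functional assay for inhibition of sodium/hydrogen exchanger (Oryctolagus cuniculus) (on this read-out lower numbers stand for stronger inhibition and higher numbers for weaker inhibition), compound 1 gives 25 nM, the lowest of the three numbers. Its nearest neighbour is compound 2, which adds a methyl on an aromatic carbon and gives 58 nM; the change is a 2.3-fold higher number from compound 1 to compound 2 (0.37 log units; beyond the scatter). Furthest away is compound 3, which gives 2800 nM, a much higher number than compound 1, though no single-change step connects these two.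

Compound 4 `Cc1cc(-c2ccccc2)c(S(C)(=O)=O)cc1C(=O)N=C(N)N` has not yet been measured in this assay. It differs from compound 1 as follows: phenyl in place of chloro on an aromatic carbon. Among the measured compounds shown here, no measured step covers exactly this change. For the measured compounds named here, the only compound that bears on it is compound 3, which also carries an aryl group at the place of the chloro of compound 1, though with two trifluoromethyl groups on that ring. Going by the values given here, compound 3 gives 2800 nM; that number stands far higher than the one of compound 1. The step from compound 1 to compound 4 is therefore expected to go in the same direction, toward a higher number, but less far than the gap to compound 3 since the entering phenyl carries no further groups. The expected step is a 12-fold higher number from compound 1 to compound 4 (1.08 log units; beyond the scatter). Compound 4 is estimated at 300 nM, within a range of 80 nM to 1500 nM.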

Compound 4, half-maximal inhibitory concentration: 19 nM
For compound 4 the middle estimate is 16-fold (1.20 log units) above the measured one; the whole stated range lies above it.
By their numbers in this assay, from the lowest: compounds 4 and 1 (each within the scatter of the next); then compound 2; then compound 3.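

In this assay the change of chloro to phenyl is a 1.3-fold lower number from compound 1 to compound 4 (0.12 log units; within the scatter), so an entering group of six carbons and one aromatic ring, in place of a single chlorine, gives a number that cannot be told apart from that of the chloro compound. This place on the core of compound 1 therefore admits an unsubstituted phenyl with no loss beyond the scatter, which compound 3 alone could not show. Compound 3 gives 2800 nM and compound 4 gives 19 nM, and as these two differ only in the two trifluoromethyl groups on the entering ring, the high number of compound 3 goes with those two groups and not with an aryl ring at this place as such.

Nothing among the data given here accounts for either result. Still open, on these data alone, is how the number would respond to a phenyl carrying one trifluoromethyl group, a methoxy group, an amine or a carboxylic acid, or to a saturated cyclohexyl ring in place of the phenyl.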